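Dropping one trifluoromethyl from the strongest urea in the set

This account rests on a few compounds, and the source may have more. Where it says the series, first, only, none or still open, it means among the compounds named here.

Three ureas have been measured in a functional assay on NCI-H522 cells (Homo sapiens) for inhibition, read by sulforhodamine B assay, with a stated time of 48 h, tested at 1 uM; on this read-out lower numbers stand for a stronger effect and higher numbers for a weaker effect at the one concentration tested. Compound 1 `O=C(Nc1cccc(-n2cc(-c3ccncc3)c(-c3cc(O)cc(Cl)c3)n2)c1)Nc1ccc(Cl)c(C(F)(F)F)c1` gives 51%, and compound 2 `O=C(Nc1cccc(-n2cc(-c3ccncc3)c(-c3cc(O)cc(Cl)c3)n2)c1)Nc1ccc(Cl)c(Cl)c1` gives 54%; the step of a number 3 percentage points higher from compound 1 to compound 2 (within the scatter) shows that swapping one halogen-type group for another there made no difference worth noting. Compound 3 `COc1cc(Cl)cc(-c2nn(-c3cccc(NC(=O)Nc4cc(C(F)(F)F)cc(C(F)(F)F)c4)c3)cc2-c2ccncc2)c1` gives 18%, the lowest number of the three and therefore the strongest effect, separated from compound 1 and from compound 2 by gaps that lie beyond the scatter.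

The next compound, compound 4 `COc1cc(Cl)cc(-c2nn(-c3cccc(NC(=O)Nc4cccc(C(F)(F)F)c4)c3)cc2-c2ccncc2)c1`, is compound 3 with a single change: hydrogen in place of trifluoromethyl on an aromatic carbon. Going by the values given here, no measured pair shows exactly this change. Among the compounds with values here, the only measured step, from compound 1 to compound 2, replaced a trifluoromethyl with chloro and stayed within the scatter, but it did not remove a group outright, and those two compounds also carry a hydroxy where compound 3 carries a methoxy, so they offer only an indirect guide. Because compound 3 stands at 18% and compounds 1 and 2 with a single substituent on that ring sit much higher, a loss of some effect is expected. The expected step is a number 17 percentage points higher from compound 3 to compound 4 (beyond the scatter), giving an estimate for compound 4 of 35%, within 15% to 60%.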

Compound 4, a percentage reported as activity, at one concentration (the size of the read-out at that concentration, not a potency): 33%
Beside the measured number, compound 4's estimate is 2 percentage points above it; measured number inside the range.
By their numbers in this assay, from the lowest: compound 3; then compound 4; then compounds 1 and 2 (each within the scatter of the next).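

In this assay, putting hydrogen in place of trifluoromethyl gives a number 15 percentage points higher from compound 3 to compound 4 (beyond the scatter), the first measured case of this group being removed outright rather than exchanged for another. This shows that the position is not indifferent to what it carries, something the earlier exchange of trifluoromethyl for chloro, made on a different pair of compounds, could not show, and that the cost of losing this one group is modest rather than total, with compound 4 at 33%. Going by these compounds alone, nothing measured so far explains why the second trifluoromethyl matters, so the step stands as an observation without a known cause.

The compounds shown leave open whether a methyl, a nitrile or an amine at this place would bring the reading back towards that of compound 3 at 18%, or whether only trifluoromethyl does so. They also leave open whether removing the same group from a compound carrying the hydroxy of compound 1 would give a step of similar size.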